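The compounds below may be only part of what the source reports. "The series", "measured", "known", "first", "only" and "open" are said of these compounds alone.

Compound 1 `c1ccc(-c2nnc(-c3cn4ccccc4n3)o2)cc1` gives 22200 nM
Compound 2 `COc1ccc(-c2nnc(-c3cn4ccccc4n3)o2)cc1` gives 13400 nM
Compound 3 `Cc1cccn2cc(-c3nnc(-c4ccccc4)o3)nc12` gives 22800 nM

These values come from a functional assay on PC-3 cells (Homo sapiens) for antiproliferative activity, read by MTT assay, with a stated time of 48 h (a lower number here means a stronger inhibitor, a higher number a weaker inhibitor), and all three lie within the usual scatter of one another, compound 3 included. Compound 4 `COc1ccc(-c2nnc(-c3cn4cccc(C)c4n3)o2)cc1` differs from compound 3 by one change, (methoxy in place of hydrogen on an aromatic carbon), namely methoxy in place of hydrogen on an aromatic carbon. Among the measured compounds shown here, the same swap gave a 1.7-fold lower number from compound 1 to compound 2 (0.22 log units; within the scatter), the closest precedent. The methyl swap gave a 1.0-fold higher number from compound 1 to compound 3 (0.01 log units; within the scatter), so the methyl offers no clear reason to expect a different outcome. Only a slightly lower number is therefore expected, with the estimated step of a 1.5-fold lower number from compound 3 to compound 4 (0.18 log units; within the scatter) staying inside the scatter. Compound 4 is estimated at 15000 nM, with an expected range from 7500 nM to 28000 nM in this test.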

Compound 4, half-maximal inhibitory concentration: 11800 nM
Compound 4: the middle estimate sits 1.3-fold (0.10 log units) above what was measured; the measured number falls inside the stated range.
By their numbers in this assay, from the lowest: compounds 4, 2, 1 and 3 (each within the scatter of the next).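

The methoxy swap can now be read on a second core, and in this assay it gives a 1.9-fold lower number from compound 3 to compound 4 (0.29 log units; within the scatter) as a step of similar size to the first: the same change on two cores in this assay, a 1.7-fold lower number (0.22 log units; within the scatter) from compound 1 to compound 2 and a 1.9-fold lower number (0.29 log units; within the scatter) from compound 3 to compound 4, 1.2-fold (0.07 log units) apart, within the scatter of two such steps. The methyl swap can also be read with methoxy in place, where it gives a 1.1-fold lower number from compound 2 to compound 4 (0.06 log units; within the scatter) and again stays small: the same change on two cores in this assay, a 1.0-fold higher number (0.01 log units; within the scatter) from compound 1 to compound 3 and a 1.1-fold lower number (0.06 log units; within the scatter) from compound 2 to compound 4, 1.2-fold (0.07 log units) apart, within the scatter of two such steps. Neither swap, on either core, separates the compounds beyond the scatter.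

On these data alone, only hydrogen and methoxy appear at this position, so whether an amine or a carboxylic acid there would move the number beyond the scatter stays open.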